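Swapping a Naphthyl for a Phenol on the Amide Side

A few compounds are considered here, and "the series" means these few. Any claim that something is new, unique, unknown or untested is made for them only; others in the source may bear on it.

Measured compounds:
- Compound 1, `CC(C)C[C@H](N)c1cc(C(F)(F)F)ccc1N1CCN(C(=O)COc2ccc3ccccc3c2)CC1`, gives 2000 nM in an assay on HEK293 cells for displacement of a labelled ligand from Melanocortin receptor 4 (Homo sapiens); on this read-out lower numbers stand for stronger inhibition and higher numbers for weaker inhibition.
- Compound 2, `CC(C)C[C@H](N)c1cc(C(F)(F)F)ccc1N1CCN(C(=O)C(C)Cc2ccc(Cl)cc2)CC1`, gives 47 nM in this assay.

For the measured compounds named here, compound 1 gives the highest of the two numbers in this assay, so it is the weaker binder of the pair; the only comparison available is a 43-fold lower number from compound 1 to compound 2 (1.63 log units; beyond the scatter), a large change made by exchanging the whole group on the carbonyl carbon.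

As far as these compounds go, compound 3, `CC(C)C[C@H](N)c1cc(C(F)(F)F)ccc1N1CCN(C(=O)COc2ccc(O)cc2)CC1`, is untested. It differs from compound 1 by 4-hydroxyphenyl in place of naphthalen-2-yl on an oxygen on a saturated carbon. Going by the values given here, no measured step makes this same change, so the one measured step only shows that the amide side tolerates big swings; it does not say which way a smaller, hydroxyl-bearing ring will move the number. The step from compound 1 is therefore expected to be modest, a 1.3-fold higher number from compound 1 to compound 3 (0.10 log units; within the scatter), with wide uncertainty. Compound 3 is estimated at 2500 nM, within 500 nM to 10000 nM.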

Compound 3, inhibition constant: 4600 nM
Compound 3: middle estimate off by 1.8-fold (0.26 log units), on the low side; the measured number falls inside the stated range.
By their numbers in this assay, from the lowest: compound 2; then compound 1; then compound 3.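

Exchanging naphthalen-2-yl for 4-hydroxyphenyl on this oxygen gives a 2.3-fold higher number from compound 1 to compound 3 (0.36 log units; beyond the scatter) in this assay, so a smaller ring carrying a hydroxyl does not recover binding on this side of the amide and instead weakens it modestly. Replacing the whole group on the carbonyl carbon moves the number far more, with a 98-fold higher number from compound 2 to compound 3 (1.99 log units; beyond the scatter), so among these three compounds the choice of the whole group counts for much more than the ring swap at its end. For the compounds shown here, nothing measured here explains either change, and the one step cannot separate losing the second ring from gaining the hydroxyl.

A plain phenyl on this oxygen would be the compound that pulls those two changes apart. As far as these compounds go, whether 4-methoxyphenyl or 4-aminophenyl would behave like 4-hydroxyphenyl also remains open.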